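The compounds below may be only part of what the source reports. "The series", "measured", "known", "first", "only" and "open" are said of these compounds alone.

For the measured compounds named here, in an ADME assay on HEK-293T cells (Homo sapiens) for cytotoxicity, read by MTT assay, with a stated time of 24 h (on this read-out lower numbers stand for higher toxicity in this test and higher numbers for lower toxicity in this test), compound 2 (`O=S(=O)(c1ccc(Br)cc1)n1c(-c2cn(-c3ccccc3)nc2-c2ccc(C(F)(F)F)cc2)nc2ccccc21`) gives 185000 nM as the highest of the two numbers so far, while compound 1 (`O=S(=O)(c1ccc(Cl)cc1)n1c(-c2cn(-c3ccccc3)nc2-c2ccc(C(F)(F)F)cc2)nc2ccccc21`) gives 75300 nM in the same test. Compound 3 (`O=S(=O)(c1ccc(C(F)(F)F)cc1)n1c(-c2cn(-c3ccccc3)nc2-c2ccc(C(F)(F)F)cc2)nc2ccccc21`) has trifluoromethyl in place of bromo on an aromatic carbon, para to a large group (trifluoromethyl in place of bromo on an aromatic carbon). Going by the values given here, the one measured step that bears on this is modest (a 2.5-fold higher number from compound 1 to compound 2 (0.39 log units; beyond the scatter)) and is bromo in place of chloro, so a step of similar or smaller size toward a lower number is expected in this assay and it may stay within the scatter. That expectation amounts to an estimated shift (a 1.4-fold lower number from compound 2 to compound 3 (0.15 log units; within the scatter)). For compound 3 the estimate is 130000 nM (expected range 55000 nM to 300000 nM).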

Compound 3, half-maximal cytotoxic concentration: 63200 nM
For compound 3 the middle estimate is 2.1-fold (0.31 log units) above the measured one, within the range that was stated.
By their numbers in this assay, from the lowest: compounds 3 and 1 (each within the scatter of the next); then compound 2.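

In this assay, trifluoromethyl at this aromatic carbon gives a 2.9-fold lower number from compound 2 to compound 3 (0.47 log units; beyond the scatter), so the gap that opened with bromo does not carry over to this group. Trifluoromethyl in place of chloro gives a 1.2-fold lower number from compound 1 to compound 3 (0.08 log units; within the scatter), which leaves bromo as the one group of the three that stands apart at this position. No measurement at hand explains this difference. As far as these compounds go, what remains open is where an amine, a carboxylic acid or a methoxy group at this carbon would fall relative to these three groups.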